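Swapping the pyridinyl for a cyclopropyl on the hydroxy acyl chain

This account rests on a few compounds, and the source may have more. Where it says the series, first, only, none or still open, it means among the compounds named here.

Compound 1 `O=C(NCc1cc(Cl)ccc1-n1cnnn1)[C@@H]1C[C@@H]2C[C@@H]2N1C(=O)[C@H](O)Cc1ccccn1` and compound 2 `COC(C)(C)[C@@H](O)C(=O)N1N=CC[C@H]1C(=O)NCc1cc(Cl)ccc1-n1cnnn1` were tested in a functional assay on a cell-free system (plasma, Homo sapiens), with a stated time of 3 min; a lower number here means a stronger inhibitor, a higher number a weaker inhibitor. In this assay compound 1 gives 1000 nM, the lower of the two numbers, while compound 2 gives 3700 nM, a gap beyond the scatter. Compound 3 `O=C(NCc1cc(Cl)ccc1-n1cnnn1)[C@@H]1C[C@@H]2C[C@@H]2N1C(=O)[C@H](O)CC1CC1` is not yet measured. It differs from compound 1 in one place: cyclopropyl in place of pyridin-2-yl on a saturated chain carbon, two bonds along the chain from a carbonyl carbon and an oxygen on a saturated carbon. Within the data shown here, with no comparable pair measured, the step of a 1.5-fold higher number from compound 1 to compound 3 (0.18 log units; within the scatter) is expected to be small, within or just beyond the scatter, and in the weaker direction. Compound 3 is therefore estimated at 1500 nM, with a likely range from 500 nM to 5000 nM.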

Compound 3, half-maximal inhibitory concentration: 1700 nM
Compound 3: the middle estimate sits 1.1-fold (0.05 log units) below what was measured; the measured number falls inside the stated range.
By their numbers in this assay, from the lowest: compounds 1 and 3 (each within the scatter of the next); then compound 2.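

In this assay, the change at this saturated chain carbon gives a 1.7-fold higher number from compound 1 to compound 3 (0.23 log units; within the scatter), so cyclopropyl serves here as well as pyridin-2-yl within the scatter. At this place, then, the number holds although the entering group has fewer heavy atoms, no aromatic ring, no ring nitrogen and no hydrogen-bond acceptor. Nothing measured on these compounds explains this outcome.

From the compounds shown here alone, how a primary amine, a carboxylic acid or a longer alkyl chain would fare at this place remains open. Also open, going by these compounds, is whether any group here can move the number beyond the scatter on the core of compound 1.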